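Nitrophenyl isomers on the benzyl arm: cytotoxicity notes

This account rests on a few compounds, and the source may have more. Where it says the series, first, only, none or still open, it means among the compounds named here.

Measured so far in a toxicity assay on NIH3T3 cells (Mus musculus) for cytotoxicity, read by resazurin assay; a higher number here means that more compound is needed for the effect, a lower number that less compound is needed:
compound 1 `COC(=O)c1ccc(NCc2cncn2Cc2ccccc2C(C)(C)C)cc1-c1ccccc1` gives "not determined" (no result reported)
compound 2 `COC(=O)c1ccc(NCc2cncn2Cc2ccc(F)cc2F)cc1-c1ccccc1` gives > 1000 nM
compound 3 `COC(=O)c1ccc(NCc2cncn2Cc2cccc([N+](=O)[O-])c2)cc1-c1ccccc1` gives > 10000 nM

Compound 3 stands at a limit of this assay, not at a number: its result reads > 10000 nM. Compound 2 likewise sits at a limit, > 1000 nM. Compound 1 carries no result in this assay. Across the three, one value sits at the limit of > 1000 nM in this assay, at which 1 of the 3 values shown sits, and one at the limit of > 10000 nM in this assay, at which 1 of the 3 values shown sits, the third is empty, so compound 3 cannot be placed relative to either other compound by a number.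

The next compound, compound 4 `COC(=O)c1ccc(NCc2cncn2Cc2ccc([N+](=O)[O-])cc2)cc1-c1ccccc1`, differs from compound 3 as follows: 4-nitrophenyl in place of 3-nitrophenyl on a saturated chain carbon bound to an aromatic nitrogen.

Within the data shown here, the only measured step, a step that the two limits leave unreadable from compound 2 to compound 3, is unreadable between its two limits and does not concern a move of the nitro group within the same ring; no measured step bears on the change to compound 4. Since compound 3 itself gives only > 10000 nM, a step beyond the scatter is not expected, and compound 4 is expected to sit at the same limit.

Compound 4 is estimated at 15000 nM, within 5000 nM to 50000 nM, an expected step that the limit leaves unreadable from compound 3 to compound 4.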

Compound 4, half-maximal effective concentration: > 10000 nM
Compound 4 was reported as a limit; the forecaster's own chance of this, stated with the estimate: 80%; the middle value does not contradict the limit.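

In this assay compound 4 gives > 10000 nM, a limit and not a number. Among these compounds, compound 2 and compound 3 also stand at limits, so no step from either to compound 4 can be read. Whether 3-nitrophenyl and 4-nitrophenyl differ at all in this assay stays open: no compound shown carries a single number there.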